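Adding a phenyl to compound 2

The compounds below may be only part of what the source reports. "The series", "measured", "known", "first", "only" and "open" are said of these compounds alone.

In a functional assay on PC-3 cells (Homo sapiens) for antiproliferative activity, read by MTT assay, with a stated time of 48 h (a lower number here means a stronger inhibitor, a higher number a weaker inhibitor), compound 1 (`O=C(CCN1C(=O)c2ccc(-c3ccccc3)cc2S1(=O)=O)Nc1ccc(C(=O)NO)cc1`) gives 8790 nM as a measured number. Compound 2 (`O=C(CCCN1C(=O)c2ccccc2S1(=O)=O)Nc1ccc(C(=O)NO)cc1`) has only a limit, > 25000 nM and no number. Compound 3 (`O=C(CCCN1C(=O)c2ccc(-c3ccccc3)cc2S1(=O)=O)Nc1ccc(C(=O)NO)cc1`) follows from compound 2 by placing phenyl in place of hydrogen on an aromatic carbon. That carbon belongs to a six-membered aromatic ring of carbon only, part of a fused or bridged system of two rings. For the measured compounds named here, no measured pair isolates this change. Going by the values given here, the only guide is compound 1, which also carries a phenyl and reads 8790 nM in this assay as a number. The expected step of an at least 2.7-fold lower number from compound 2 to compound 3 (0.44 log units; beyond the scatter) therefore points towards a stronger inhibitor, with its size poorly fixed. For compound 3 the estimated value is 9000 nM with an expected range from 3500 nM to 25000 nM on this reading.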

Compound 3, half-maximal inhibitory concentration: > 25000 nM
Compound 3: no number, only a limit; the forecaster's own chance of this, stated with the estimate: 20%; middle value at least 2.7-fold (0.44 log units) away from the limit.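

For the compounds shown here, compound 2 and compound 3 both carry only a limit, so no step between them can be read: the limit of > 25000 nM in this assay, at which 2 of the 3 values shown sit. Still open, as far as these compounds go, is whether phenyl in place of hydrogen on an aromatic carbon changes the antiproliferative activity of compound 2 at all, and in which direction.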